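The source may report more compounds than this note shows. Statements on the series, on what has been measured and on what is new or still open speak of the compounds shown alone.

Measured so far:
compound 1, `O=C1CNC(=O)N1C[C@H]1CN(c2ccc(-n3cc(-c4ccccn4)cn3)c(F)c2)C(=O)O1` — 1630000 nM
compound 2, `O=C1O[C@@H](Cn2ccnn2)CN1c1ccc(-n2cc(-c3ccccn3)cn2)c(F)c1` — 247000 nM

Within the data shown here, compound 2 stands at the lower of the two numbers in a physicochemical assay for solubility, read by HPLC, with a stated time of 24 h; on this read-out higher numbers stand for higher solubility and lower numbers for lower solubility; its nearest neighbour is compound 1, and the one step known, a 6.6-fold lower number from compound 1 to compound 2 (0.82 log units; beyond the scatter), lies beyond the scatter. Compound 3, `O=CNC[C@H]1CN(c2ccc(-n3cc(-c4ccccn4)cn3)c(F)c2)C(=O)O1`, has not yet been measured in this assay. It differs from compound 2 by formylamino in place of 1H-1,2,3-triazol-1-yl on a saturated chain carbon bound to a saturated ring carbon. Among the measured compounds shown here, the only step that bears on this change is the one from compound 1 to compound 2, where a carbonyl-bearing ring gave way to the triazole and the number fell by a 6.6-fold lower number from compound 1 to compound 2 (0.82 log units; beyond the scatter). Going the other way, from the triazole to a small carbonyl-bearing group, compound 3 is expected to move back toward the number of compound 1, so a rise of about a 2.8-fold higher number from compound 2 to compound 3 (0.45 log units; beyond the scatter) is estimated. For compound 3 the expected value is 700000 nM, in a range from 250000 nM to 2000000 nM.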

Compound 3, solubility: 217000 nM
For compound 3 the middle estimate is 3.2-fold (0.51 log units) above the measured one; the whole stated range lies above it.
By their numbers in this assay, from the lowest: compounds 3 and 2 (each within the scatter of the next); then compound 1.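

In this assay formylamino and 1H-1,2,3-triazol-1-yl on this saturated chain carbon cannot be told apart, with a 1.1-fold lower number from compound 2 to compound 3 (0.06 log units; within the scatter) even though the two groups differ in ring, heavy atoms and hydrogen-bond donors. The 2,5-dioxoimidazolidin-1-yl group of compound 1 now stands apart from both, with a 7.5-fold lower number from compound 1 to compound 3 (0.88 log units; beyond the scatter) alongside the earlier step, and a carbonyl in the group is not enough to put a compound level with compound 1. Nothing measured here explains why these groups read as they do.

Going by these compounds, it remains open whether an amine, a carboxylic acid or a longer chain at this place would read with compound 1 or with compound 2 and compound 3. On these data alone, it is also open which part of 2,5-dioxoimidazolidin-1-yl carries the gap.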